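Swapping Iodo for Trifluoromethyl on Two Related Cores

The source may report more compounds than this note shows. Statements on the series, on what has been measured and on what is new or still open speak of the compounds shown alone.

Three compounds have been measured in a functional assay on IMR-32 cells (Homo sapiens) for inhibition, read by sulforhodamine B assay, with a stated time of 48 h; on this read-out lower numbers stand for stronger inhibition of growth and higher numbers for weaker inhibition of growth:

compound 1, `O=C(N/N=C/C1=C(Cl)c2ccccc2CCC1)c1cccc(I)c1`, gives 7600 nM
compound 2, `O=C(N/N=C/C1=C(Cl)c2ccccc2CCC1)c1cccc(C(F)(F)F)c1`, gives 2000 nM
compound 3, `Cc1cc2c(cc1C)C(Cl)=C(/C=N/NC(=O)c1cccc(I)c1)CCC2`, gives 1900 nM

Compound 2 differs from compound 1 by trifluoromethyl in place of iodo on an aromatic carbon and this change brought a 3.8-fold lower number from compound 1 to compound 2 (0.58 log units; beyond the scatter). Compound 3 has a different core; the difference between the cores of compound 1 and compound 3 is not broken down here.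

Compound 4, `Cc1cc2c(cc1C)C(Cl)=C(/C=N/NC(=O)c1cccc(C(F)(F)F)c1)CCC2`, has not yet been measured. It differs from compound 3 by trifluoromethyl in place of iodo on an aromatic carbon, the same change as that made from compound 1 to compound 2. Compound 4 is expected to show a 3.2-fold lower number from compound 3 to compound 4 (0.50 log units; beyond the scatter) in this assay, a step of similar size to the earlier one, because a 3.8-fold lower number from compound 1 to compound 2 (0.58 log units; beyond the scatter). The estimate for compound 4 is 600 nM, with a range expected from 250 nM to 1500 nM.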

Compound 4, concentration for 50% growth inhibition: 7800 nM
Estimate against measurement, compound 4: 13-fold (1.11 log units) below, and the stated range ends below it.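

In this assay, trifluoromethyl in place of iodo did not carry over from one core to the other: the swap gave a 4.1-fold higher number from compound 3 to compound 4 (0.61 log units; beyond the scatter) and so ran opposite to the step on the core of compound 1. The two steps differ by more than the usual scatter: the same change on two cores in this assay, a 3.8-fold lower number (0.58 log units; beyond the scatter) from compound 1 to compound 2 and a 4.1-fold higher number (0.61 log units; beyond the scatter) from compound 3 to compound 4, 16-fold (1.19 log units) apart, beyond the scatter of two such steps. This shows that the outcome of this swap depends on the core in these two pairs, but it does not show which part of the core matters or why the direction reverses.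

The compounds shown leave open whether another group in the same place, such as bromo or an amine, would behave alike on both cores. They also leave open which way the swap would go on a third core.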